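A Larger Ring on the Amine Nitrogen: Cytotoxicity Outlook

The source may report more compounds than this note shows. Statements on the series, on what has been measured and on what is new or still open speak of the compounds shown alone.

Compound 3 `Cc1c(Cc2ccccc2)c(=O)oc2cc(OCC(O)CNc3nccs3)ccc12` is the only one of the three with a number in an ADME assay on A549 cells (Homo sapiens) for cytotoxicity, read by CellTiter-Glo (a lower number here means that less compound is tolerated, a higher number that more compound is tolerated), where compound 3 gives 93000 nM. Compound 1 `Cc1c(Cc2ccccc2)c(=O)oc2cc(OCC(O)CNCC3CC3)ccc12` reaches only a limit, giving > 100000 nM. Compound 2 `Cc1c(Cc2ccccc2)c(=O)oc2cc(OCC(O)CNc3cc([N+](=O)[O-])ccc3O)ccc12` likewise reaches only a limit, giving > 100000 nM. The steps of an at least 1.0-fold lower number from compound 1 to compound 3 (0.03 log units; that floor lies within the scatter) and an at least 1.0-fold lower number from compound 2 to compound 3 (0.03 log units; that floor lies within the scatter) thus stay within the scatter, with both other values sitting at the limit of > 100000 nM in this assay, at which 2 of the 3 values shown sit. Compound 4 `Cc1ccc2nc(NCC(O)COc3ccc4c(C)c(Cc5ccccc5)c(=O)oc4c3)sc2c1` differs from compound 3 in one place: 6-methyl-1,3-benzothiazol-2-yl in place of 1,3-thiazol-2-yl on an amine nitrogen. Among the measured compounds shown here, no measured step covers this change; the two steps onto the 1,3-thiazol-2-yl group were small, so no move beyond the scatter is expected. Compound 4 is estimated at 80000 nM, between 35000 nM and 150000 nM, an expected step of a 1.2-fold lower number from compound 3 to compound 4 (0.07 log units; within the scatter).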

Compound 4, half-maximal cytotoxic concentration: > 100000 nM
Compound 4 was reported as a limit; the forecaster's own chance of this, stated with the estimate: 50%; at least 1.2-fold (0.09 log units) between middle value and limit.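

Swapping 1,3-thiazol-2-yl for 6-methyl-1,3-benzothiazol-2-yl on the amine nitrogen adds a six-membered aromatic ring of carbon only, and the result in this assay is an at least 1.0-fold higher number from compound 3 to compound 4 (0.03 log units; that floor lies within the scatter). So this position carries the larger group without any drop in the number, though compound 4 gives only a limit and the true size of the step stays unknown. The steps to compound 4 from compound 1 and compound 2 cannot be read, and compound 3 alone still carries a number: the limit of > 100000 nM in this assay, at which 3 of the 4 values shown sit.

Going by these compounds, whether a morpholine or a chain ending in a carboxylic acid on this nitrogen would give a readable number stays open.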